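This account rests on a few compounds, and the source may have more. Where it says the series, first, only, none or still open, it means among the compounds named here.

In a functional assay on L1210 cells (Mus musculus) for cytotoxicity, read by cell counting, with a stated time of 2 days (on this read-out lower numbers stand for stronger inhibition and higher numbers for weaker inhibition), compound 1 `C=C(Br)C(=O)Nc1cccc(/C=C2\SC(=O)N(Cc3ccc(Cl)cc3)C2=O)c1` gives 940 nM. Compound 2 `Nc1cccc(/C=C2\SC(=O)N(Cc3cccc(F)c3)C2=O)c1` gives 199000 nM in this assay. Compound 3 `Nc1cccc(/C=C2\SC(=O)N(Cc3ccc(C(F)(F)F)cc3)C2=O)c1` reaches only a limit of the assay in this assay, namely > 250000 nM. Compound 3 thus stands at the weak end of the values shown, where (the limit of > 250000 nM in this assay, at which 1 of the 3 values shown sits). Compound 4 `Nc1cccc(/C=C2\SC(=O)N(Cc3ccc(Cl)cc3)C2=O)c1` has not yet been tested in this assay. The change from compound 3 to compound 4 is chloro in place of trifluoromethyl on an aromatic carbon. For the measured compounds named here, no measured step between such neighbours exists here; compound 2, which also carries the free amine, gives 199000 nM, and that weak result is the nearest guide. The expected step is an at least 1.6-fold lower number from compound 3 to compound 4 (0.22 log units; that floor lies within the scatter), a small gain that need not exceed the scatter. Compound 4 is estimated at 150000 nM, with a range from 40000 nM to 400000 nM.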

Compound 4, half-maximal inhibitory concentration: 218000 nM
Estimate against measurement, compound 4: 1.5-fold (0.16 log units) below, and the stated range covers the measured number.
By their numbers in this assay, from the lowest: compound 1; then compounds 2 and 4 (each within the scatter of the next). At a limit, above all of these: compound 3.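

Chloro in place of trifluoromethyl gives only an at least 1.1-fold lower number from compound 3 to compound 4 (0.05 log units; that floor lies within the scatter), and compound 3 remains a limit of the assay, not a number: the limit of > 250000 nM in this assay, at which 1 of the 4 values shown sits.

4-Chlorophenyl in place of 3-fluorophenyl gives a 1.1-fold higher number from compound 2 to compound 4 (0.04 log units; within the scatter), so this matched pair of free amines shows no separation. For the compounds shown here, the large change lies on the nitrogen: hydrogen in place of (1-bromoethenyl)carbonyl gives a 230-fold higher number from compound 1 to compound 4 (2.37 log units; beyond the scatter), the first matched step to show that this group separates compound 1 from compound 4.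

Open, as far as these compounds go, is whether a methoxy group or a nitrile on the aromatic ring would change the free amine's result, and whether a chloroacetyl group on the nitrogen would match (1-bromoethenyl)carbonyl.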